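The source may hold more compounds than are shown below. What is called first, only, known or untested is meant among the compounds shown, and "the series" means these compounds.

Measured so far in a functional assay on CHP-134 cells (Homo sapiens) for antiproliferative activity, with a stated time of 72 h; a higher number here means a weaker inhibitor, a lower number a stronger inhibitor:
Compound 1 `Cc1ccc(CNC(=O)CCN(Cc2ccc(C(=O)NO)cc2)C(=O)c2ccc(N(C)C)cc2)cc1` reads 420 nM
Compound 2 `COc1cc(OC)cc(C(=O)N(CCC(=O)NCc2ccccc2)Cc2ccc(C(=O)NO)cc2)c1` reads 12300 nM
Compound 3 `CN(C)c1ccc(C(=O)N(CCC(=O)NCc2ccc(Cl)cc2)Cc2ccc(C(=O)NO)cc2)cc1` reads 610 nM

In this assay compound 3 (at 610 nM) lies within the scatter of compound 1 (at 420 nM), while compound 2 stands far apart from both (at 12300 nM).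

Compound 4 `CN(C)c1ccc(C(=O)N(CCC(=O)NCc2ccccc2)Cc2ccc(C(=O)NO)cc2)cc1` departs from compound 3 at one place, with hydrogen in place of chloro on an aromatic carbon, para to a large group, so that 4-chlorobenzyl becomes benzyl.

Among the compounds with values here, one measured step bears directly on this change. Chloro in place of methyl on that aromatic carbon gave a small change (a 1.5-fold higher number from compound 1 to compound 3 (0.16 log units; within the scatter)), which stays within the scatter. Within the data shown here, compound 2 also carries the benzyl end, but it differs from compound 4 elsewhere as well, so it offers no measured step for this change. Among the measured compounds shown here, no compound with hydrogen at this place and otherwise the same structure has been measured yet, so the expectation rests on that single step.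

For the measured compounds named here, with so little moved by the one exchange seen here, no step beyond the scatter is expected in this assay, and the direction is not firmly expected either. The expected step is small (a 1.2-fold lower number from compound 3 to compound 4 (0.09 log units; within the scatter)) by this estimate. For compound 4 the estimated value is 500 nM (expected range 250 nM to 1000 nM).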

Compound 4, half-maximal inhibitory concentration: 1160 nM
Estimate against measurement, compound 4: 2.3-fold (0.37 log units) below, outside the stated range (above it).
By their numbers in this assay, from the lowest: compounds 1, 3 and 4 (each within the scatter of the next, the first and the last beyond it); then compound 2.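

In this assay, within the data shown here, the first step with hydrogen at this aromatic carbon, a 1.9-fold higher number from compound 3 to compound 4 (0.28 log units; within the scatter), stays within the scatter, so the 4-chlorobenzyl and benzyl ends cannot be told apart here. Hydrogen in place of methyl at the same carbon, however, gives a 2.8-fold higher number from compound 1 to compound 4 (0.44 log units; beyond the scatter), which lies beyond the scatter and shows that this position is not wholly indifferent to its substituent, although the step is modest. With the benzyl end held fixed, 4-(dimethylamino)phenyl in place of 3,5-dimethoxyphenyl on the carbonyl carbon gives a much larger step in the reverse direction of number, an 11-fold lower number from compound 2 to compound 4 (1.03 log units; beyond the scatter), and no evidence is available on what lies behind any of these differences.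

The compounds shown leave open how a fluoro, methoxy or trifluoromethyl group at this aromatic carbon would compare with methyl, chloro and hydrogen. They also leave open whether the step between hydrogen and methyl at this carbon would hold with 3,5-dimethoxyphenyl on the carbonyl carbon.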